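The compounds below may be only part of what the source reports. "The series", "measured", "known", "first", "only" and "open" are said of these compounds alone.

In a functional assay on HeLa cells (Homo sapiens) for antiproliferative activity, read by MTT assay, with a stated time of 72 h (on this read-out lower numbers stand for stronger inhibition and higher numbers for weaker inhibition), two compounds that share one core have been measured so far. Compound 1 `CC(C)(C)c1cn(C[C@H](O)[C@H]2OC(=O)C(OCc3ccccc3)=C2OCc2ccccc2)nn1` gives 18300 nM and compound 2 `Cc1ccc(S(=O)(=O)NCc2cn(C[C@H](O)[C@H]3OC(=O)C(OCc4ccccc4)=C3OCc3ccccc3)nn2)cc1` gives 14400 nM, so compound 2 stands level with compound 1 within the usual scatter of repeat measurements. Compound 3 `O=C1O[C@H]([C@@H](O)Cn2ccnn2)C(OCc2ccccc2)=C1OCc1ccccc1` differs from compound 2 in one place, with hydrogen in place of (((4-methylphenyl)sulfonyl)amino)methyl on an aromatic carbon. Among the compounds with values here, only one measured step bears on this, the exchange of tert-butyl for that same group: a 1.3-fold lower number from compound 1 to compound 2 (0.10 log units; within the scatter), which stays within the scatter. Within the data shown here, no measured compound yet shows what a bare hydrogen does here, so the guide is thin. On that single step, no change beyond the scatter is expected in this assay. The expected step is a 1.3-fold higher number from compound 2 to compound 3 (0.10 log units; within the scatter). For compound 3 the estimated value is 18000 nM, with an expected range of 8000 nM to 42000 nM.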

Compound 3, half-maximal inhibitory concentration: > 100000 nM
Compound 3: only a limit was reported; the forecaster's own chance of this, stated with the estimate: 15%; middle value at least 5.5-fold (0.74 log units) from the limit.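

Putting a group on this aromatic carbon of the five-membered ring turns out to matter: hydrogen in place of (((4-methylphenyl)sulfonyl)amino)methyl gives an at least 6.9-fold higher number from compound 2 to compound 3 (0.84 log units; beyond the scatter) and hydrogen in place of tert-butyl gives an at least 5.4-fold higher number from compound 1 to compound 3 (0.73 log units; beyond the scatter) in this assay. Compound 1 and compound 2 stood level within the scatter despite their very different groups, which hid what compound 3 now reveals: in these three compounds, either large group gives measurable activity and a bare hydrogen does not. Going by these compounds, for compound 3 the result of > 100000 nM is a limit and not a number, so the full size of both steps stays unknown: the limit of > 100000 nM in this assay, at which 1 of the 3 values shown sits.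

On these data alone, what the two large groups share that hydrogen lacks remains open. As far as these compounds go, whether a small methyl, a longer alkyl chain or a group carrying an amine would restore activity also remains open.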